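This account rests on a few compounds, and the source may have more. Where it says the series, first, only, none or still open, it means among the compounds named here.

Working notes on the series.

Three compounds of the shared core have numbers in a functional assay for activation of Alpha-1A adrenergic receptor (Homo sapiens), read by calcium flux; on this read-out lower numbers stand for an effect already at smaller amounts and higher numbers for an effect only at larger amounts of compound. Compound 1 `c1cnc(-c2ccccc2OCC2=NCCN2)nc1` gives 1260 nM. Compound 2 `c1csc(-c2ccccc2OCC2=NCCN2)c1` gives 1 nM. Compound 3 `c1c[nH]c(-c2ccccc2OCC2=NCCN2)c1` gives 1.26 nM. Compound 3 stands second highest of the three; its nearest neighbour is compound 2, with a 1.3-fold higher number from compound 2 to compound 3 (0.10 log units; within the scatter), and its furthest is compound 1, with a 1000-fold lower number from compound 1 to compound 3 (3.00 log units; beyond the scatter). The parallel step a 1300-fold lower number from compound 1 to compound 2 (3.10 log units; beyond the scatter) is of the same size.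

Compound 4 `c1ccc(-c2cc[nH]n2)c(OCC2=NCCN2)c1` is not yet measured. The change (1H-pyrazol-3-yl in place of 1H-pyrrol-2-yl on an aromatic carbon). The five-membered ring keeps its hydrogen-bond donor and gains one hydrogen-bond acceptor. The two five-membered rings of compound 2 and compound 3 sit within the scatter of each other, while compound 1, whose six-membered ring carries two nitrogen atoms and no donor, lies far higher. Compound 4 sits between these cases, so a moderate rise is expected, estimated as a 4.0-fold higher number from compound 3 to compound 4 (0.60 log units; beyond the scatter). Compound 4 is expected to give about 5 nM in this assay, within 0.8 nM to 40 nM.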

Compound 4, half-maximal effective concentration: 5.01 nM
Beside the measured number, compound 4's estimate is 1.0-fold (0.00 log units) below it; the range from low to high includes it.
By their numbers in this assay, from the lowest: compounds 2 and 3 (each within the scatter of the next); then compound 4; then compound 1.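

Within the five-membered rings this position is not flat. Thiophen-2-yl and 1H-pyrrol-2-yl could not be told apart, but 1H-pyrazol-3-yl, with its extra hydrogen-bond acceptor and the donor kept, brings a modest rise in this assay (a 4.0-fold higher number from compound 3 to compound 4 (0.60 log units; beyond the scatter); a 5.0-fold higher number from compound 2 to compound 4 (0.70 log units; beyond the scatter)). That rise is small beside the large gap to the pyrimidin-2-yl compound (a 250-fold lower number from compound 1 to compound 4 (2.40 log units; beyond the scatter)), so all three five-membered rings stay far from compound 1. Nothing at hand bears on the reason for either step.

Still open, going by these compounds, is whether the rise follows the added ring nitrogen as such or its place in the ring, which a 1H-imidazol-2-yl group would test. A phenyl group would test ring size apart from ring nitrogen, and an N-methylpyrazolyl group would test the role of the donor.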